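This account rests on a few compounds, and the source may have more. Where it says the series, first, only, none or still open, it means among the compounds named here.

Working notes on the series in a functional assay with Homo sapiens as the target; on this read-out higher numbers stand for weaker inhibition and lower numbers for stronger inhibition. Compound 1 `CC(C)[C@H](NC(=O)COc1cccc2ccccc12)C(=O)N[C@@H](CC(=O)O)C(=O)COc1ccc(F)cc1` gives 14300 nM, compound 2 `CC(C)[C@H](NC(=O)COc1cccc2ccccc12)C(=O)N[C@@H](CC(=O)O)C(=O)COc1cc(F)cc(F)c1` gives 15900 nM, and compound 3 `CC(C)[C@H](NC(=O)COc1cccc2ccccc12)C(=O)N[C@@H](CC(=O)O)C(=O)COc1c(F)cc(F)cc1F` gives 14900 nM. Compound 3 stands level with both of the others, and the steps that reach it read a 1.0-fold higher number from compound 1 to compound 3 (0.02 log units; within the scatter) and a 1.1-fold lower number from compound 2 to compound 3 (0.03 log units; within the scatter).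

The next member is compound 4 `CC(C)[C@H](NC(=O)COc1cccc2ccccc12)C(=O)N[C@@H](CC(=O)O)C(=O)COc1c(F)c(F)c(F)c(F)c1F`, and the change sits on an oxygen on a saturated carbon: 2,3,4,5,6-pentafluorophenyl in place of 2,4,6-trifluorophenyl on an oxygen on a saturated carbon. Within the data shown here, three measured steps bear on it, since each exchanges one fluorinated phenyl for another at this same place. Besides the two above, the third reads a 1.1-fold higher number from compound 1 to compound 2 (0.05 log units; within the scatter). All three stay within the scatter, whichever way the fluorine count moves, so these compounds give no trend to extend. No measured compound carries the 2,3,4,5,6-pentafluorophenyl group, so the expectation goes somewhat beyond the measured range, and the range is set wider for that reason. No step beyond the scatter is expected in this assay, and no direction is favoured. The expected step is a 1.0-fold higher number from compound 3 to compound 4 (0.00 log units; within the scatter). Compound 4 is estimated at 15000 nM, with an expected range of 9000 nM to 25000 nM.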

Compound 4, half-maximal inhibitory concentration: 8890 nM
Beside the measured number, compound 4's estimate is 1.7-fold (0.23 log units) above it, outside the stated range (below it).
By their numbers in this assay, from the lowest: compounds 4, 1, 3 and 2 (each within the scatter of the next).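

In this assay, bringing in the 2,3,4,5,6-pentafluorophenyl group on an oxygen on a saturated carbon gives a 1.7-fold lower number from compound 3 to compound 4 (0.22 log units; within the scatter) and a 1.8-fold lower number from compound 2 to compound 4 (0.25 log units; within the scatter) and also a 1.6-fold lower number from compound 1 to compound 4 (0.21 log units; within the scatter) and so adds a fifth fluorine to this place without a step beyond the scatter. Among these compounds, these three steps are larger than those among the earlier compounds and share one sign, which the earlier steps did not, but all remain within the scatter, and compound 2 and compound 3 do not follow fluorine count in any printed order, so the four compounds support tolerance of this change at this place and no trend with the number of fluorines. No supporting data bear on what lies behind these small steps.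

On these data alone, it remains open whether a phenyl group with no fluorine, or one carrying an amine or a carboxylic acid, would stay within the same narrow band in this assay or leave it. Equally open, as far as these compounds go, is whether a saturated alkyl chain in place of the aromatic ring on this oxygen would keep the read-out where these four compounds hold it.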